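The source may hold more compounds than are shown below. What is called first, only, known or untested is meant among the compounds shown, and "the series" means these compounds.

- compound 1 `O=C1C=CCC/C1=C\C=C\c1ccccc1` gives 4500 nM in the test below
- compound 2 `O=C1C=CCC/C1=C\C=C\c1ccccc1[N+](=O)[O-]` gives 4400 nM in the same test

Both numbers come from a functional assay on HGC-27 cells (Homo sapiens) for cytotoxicity, read by MTT assay, with a stated time of 72 h (on this read-out higher numbers stand for weaker inhibition and lower numbers for stronger inhibition), and, with only these two measured, compound 2 stands level with compound 1 within the usual scatter. The next compound is compound 3 `COc1ccccc1/C=C/C=C1\CCC=CC1=O` which carries methoxy in place of nitro on an aromatic carbon, ortho to a large group (methoxy in place of nitro on an aromatic carbon). Going by the values given here, one measured step bears on this change: nitro in place of hydrogen on an aromatic carbon gave a 1.0-fold lower number from compound 1 to compound 2 (0.01 log units; within the scatter) and so made no visible difference. Methoxy itself has no measured step on this core, so a single step is thin evidence. No step beyond the scatter is therefore expected in this assay in either direction. The estimated step is a 1.1-fold lower number from compound 2 to compound 3 (0.04 log units; within the scatter) and it is only an expectation. Compound 3 is expected at 4000 nM with an estimated range from 1500 nM to 10000 nM in this test.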

Compound 3, half-maximal inhibitory concentration: 3100 nM
Estimate against measurement, compound 3: 1.3-fold (0.11 log units) above; measured number inside the range.
By their numbers in this assay, from the lowest: compounds 3, 2 and 1 (each within the scatter of the next).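

In this assay, methoxy in place of nitro gave a 1.4-fold lower number from compound 2 to compound 3 (0.15 log units; within the scatter), and methoxy in place of hydrogen gave a 1.5-fold lower number from compound 1 to compound 3 (0.16 log units; within the scatter). The earlier pair compared only hydrogen and nitro on this aromatic carbon, ortho to a large group; a third group now also stays within the scatter of both, so three different substituents at this position cannot be told apart in this test. Nothing available explains why these three compounds read alike.

On these data alone, it remains open whether an amine, a carboxylic acid or a longer chain on this carbon would move the number beyond the scatter. As far as these compounds go, it is also open whether methoxy or nitro on another carbon of the aromatic ring would read the same, or whether these three compounds would stay level on other cell lines.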